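Notes on a second methoxy group in the series

The source may hold more compounds than are shown below. What is called first, only, known or untested is meant among the compounds shown, and "the series" means these compounds.

Of the compounds shown here, two on a shared core have been measured so far. In a functional assay on MDA-MB-231 cells (Homo sapiens) for antiproliferative activity, read by MTT assay, with a stated time of 72 h (a lower number here means a stronger inhibitor, a higher number a weaker inhibitor), compound 1 (`O=C(CCc1cccc2c1B(O)OC2)Nc1ccccc1`) gives 230 nM. Compound 2 (`COc1ccc(NC(=O)CCc2cccc3c2B(O)OC3)cc1`) gives 850 nM, the higher of the two numbers, which makes it the weaker inhibitor of the pair.

The next compound is compound 3 (`COc1ccc(NC(=O)CCc2cccc3c2B(O)OC3)cc1OC`). Its structural change is methoxy in place of hydrogen on an aromatic carbon, with methoxy in place of hydrogen on an aromatic carbon, ortho to a methoxy group and meta to a large group.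

Among the measured compounds shown here, only one measured step bears on this change: a 3.7-fold higher number from compound 1 to compound 2 (0.57 log units; beyond the scatter). It is the same kind of replacement, a modest step beyond the scatter, and it went towards a higher number. For the measured compounds named here, a single step sets no rule, and no measured compound yet carries two methoxy groups. The expectation in this assay is therefore a step in the same direction, of similar or smaller size. The estimated step is a 2.1-fold higher number from compound 2 to compound 3 (0.33 log units; beyond the scatter). For compound 3 the expected value is 1800 nM, with an estimated range of 600 nM to 5000 nM.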

Compound 3, half-maximal inhibitory concentration: > 100000 nM
Compound 3: a limit, no number; the forecaster's own chance of this, stated with the estimate: 5%; at least 55-fold (1.74 log units) between middle value and limit.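

In this assay, methoxy in place of hydrogen gives an at least 110-fold higher number from compound 2 to compound 3 (2.07 log units; beyond the scatter), whereas the same replacement on the earlier pair gave a 3.7-fold higher number from compound 1 to compound 2 (0.57 log units; beyond the scatter). The replacement therefore does not carry a step of similar size to this position, ortho to a methoxy group and meta to a large group: the modest step of the earlier pair gives way to a large one, and two methoxy groups on this six-membered aromatic ring are far from additive in the way a single step might have suggested. As far as these compounds go, the reading for compound 3 is a limit of the assay and not a number, so the full size of this step stays unknown: the limit of > 100000 nM in this assay, at which 1 of the 3 values shown sits.

Whether this drop belongs to a methoxy group at this position alone or to the two methoxy groups together stays open, since no compound shown carries a single methoxy group here. From the compounds shown here alone, it is also open how a fluorine, a hydroxy group or an amine at this position would read in this assay, and so whether the result is specific to methoxy.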